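Dimethoxybenzamide step in a weakly active pyrimidine series

A few compounds are considered here, and "the series" means these few. Any claim that something is new, unique, unknown or untested is made for them only; others in the source may bear on it.

Measured compounds:
- compound 1, `Cc1ccc(Nc2ncc3c(n2)N(C)C(=O)N(c2cc(NC(=O)c4cc(C(C)(C)C)cc(C(C)(C)C)c4)ccc2C)C3)cc1N`: > 10000 nM
- compound 2, `CNc1nc(Nc2ccc(C)c([N+](=O)[O-])c2)ncc1C(=O)Nc1cc(NC(=O)c2ccccc2OC)ccc1C`: > 10000 nM
- compound 3, `CNc1nc(Nc2ccc(C)c([N+](=O)[O-])c2)ncc1C(=O)Nc1cc(NC(=O)c2cccc(OC)c2)ccc1C`: 6310 nM

In an ADME assay on BaF3 cells (Mus musculus) for antiproliferative activity, read by CellTiter-Glo and CCK-8 assay, with a stated time of 72 h (on this read-out higher numbers stand for weaker inhibition of growth and lower numbers for stronger inhibition of growth), compound 1 returns only a limit, > 10000 nM. Compound 2 likewise gives only a limit in this assay, > 10000 nM. Within the data shown here, compound 3 is the one compound of the three with a number in this assay, 6310 nM. Compound 3 therefore stands alone as the only measured point, and it sits at the weak end of the measurable range.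

Among the measured compounds shown here, the single measured step, an at least 1.5-fold lower number from compound 2 to compound 3 (0.19 log units; that floor lies within the scatter), moves the methoxy group from one position of the benzamide ring to another; its size is uncertain because of the limit of > 10000 nM in this assay, at which 2 of the 3 values shown sit, the limit at which two of the three values sit.

Compound 4, `CNc1nc(Nc2ccc(C)c([N+](=O)[O-])c2)ncc1C(=O)Nc1cc(NC(=O)c2cc(OC)cc(OC)c2)ccc1C`, is compound 3 with a further change: methoxy in place of hydrogen on an aromatic carbon. For the measured compounds named here, no measured step adds a second methoxy group, so the one step bearing on it is that from compound 2 to compound 3, which at most shows that a methoxy group in the 3-position is compatible with a measurable number. A step of no more than the usual scatter is expected in this assay, with no clear direction; the expected step is a 1.3-fold lower number from compound 3 to compound 4 (0.10 log units; within the scatter). Compound 4 is therefore estimated at 5000 nM, in the range 2000 nM to 15000 nM, with a real chance that this assay again reports only a limit.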

Compound 4, concentration for 50% growth inhibition: > 10000 nM
Compound 4: only a limit was reported; the forecaster's own chance of this, stated with the estimate: 35%; middle value at least 2.0-fold (0.30 log units) away from the limit.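

Adding a second methoxy group, the change from 3-methoxyphenyl to 3,5-dimethoxyphenyl, brings no visible gain in this assay, and the step reads an at least 1.5-fold higher number from compound 3 to compound 4 (0.19 log units; that floor lies within the scatter). The new group sits meta to the existing methoxy group and meta to a large group, and this substitution does not extend the measurable range of the series, so compound 3 remains the only compound shown with a number rather than a limit. The step between compound 2 and compound 4 cannot be read, and the true size of the change at compound 4 remains unknown because the values are mostly limits: the limit of > 10000 nM in this assay, at which 3 of the 4 values shown sit.

From the compounds shown here alone, whether a group other than methoxy at this place on the ring, such as an amine, a carboxylic acid or a longer chain, would improve on compound 3 at 6310 nM remains open. Also open, going by these compounds, are how far compound 4 really lies from compound 3 and whether any change on this ring alone can move the series well clear of the limit.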